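Replacing Isopropyl with Methyl at the Assay Limit

The source may hold more compounds than are shown below. What is called first, only, known or untested is meant among the compounds shown, and "the series" means these compounds.

Compound 1 (`CSC(=O)c1c(O[C@@H]2O[C@H](CO)[C@@H](O)[C@H](O)[C@H]2O)c(C)c(O)c(C)c1C(C)C`) is the starting point, and only a limit is known for it. In a functional assay on PC-3 cells (Homo sapiens) for cytotoxicity, read by sulforhodamine B assay, with a stated time of 72 h (on this read-out higher numbers stand for weaker inhibition and lower numbers for stronger inhibition), compound 1 gives > 40000 nM, which is a limit of the assay and not a number. Among the compounds with values here, its one measured neighbour is compound 2 (`CCc1c(C)c(O)c(C)c(O[C@@H]2O[C@H](CO)[C@@H](O)[C@H](O)[C@H]2O)c1C(=O)SC`). Compound 2 gives > 40000 nM, which is also a limit. The measured series therefore stands at the limit of > 40000 nM in this assay, at which 2 of the 2 values shown sit.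

Compound 3 (`CSC(=O)c1c(C)c(C)c(O)c(C)c1O[C@@H]1O[C@H](CO)[C@@H](O)[C@H](O)[C@H]1O`) carries methyl in place of isopropyl on an aromatic carbon, ortho to a (methylsulfanyl)carbonyl group, with the rest of the core of compound 1 unchanged: methyl in place of isopropyl on an aromatic carbon. Within the data shown here, the one measured step that bears on this change touches the same isopropyl group, with hydrogen in place of methyl. That is a step that the two limits leave unreadable from compound 1 to compound 2, so it offers no size to carry over. No step beyond the usual scatter is therefore expected in this assay, in either direction, and a further limit is the likeliest report. The expected result is a number no higher from compound 1 to compound 3 (the limit leaves the size open). For compound 3 the estimate is 40000 nM, with an expected range from 20000 nM to 80000 nM.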

Compound 3, half-maximal inhibitory concentration: > 40000 nM
Compound 3: only a limit was reported; the forecaster's own chance of this, stated with the estimate: 85%; the middle value lies on the limit itself.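

In this assay compound 3 gives > 40000 nM, which is a limit of the assay and not a number. No step among compound 1, compound 2 and compound 3 can therefore be read, and the series remains at a single limit: the limit of > 40000 nM in this assay, at which 3 of the 3 values shown sit.

The compounds shown leave open how far each of the three lies beyond that limit, and whether these changes alter the read-out at all.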